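Trading Trifluoromethoxy for Ethyl on the Phenylamino Group

The source may report more compounds than this note shows. Statements on the series, on what has been measured and on what is new or still open speak of the compounds shown alone.

Compound 2 `COc1cc2ncnc(Nc3ccc(OC(F)(F)F)cc3)c2cc1OCCCCC(=O)Nc1ccc(S(N)(=O)=O)cc1` gives in a functional assay on A549 cells (Homo sapiens) for antiproliferative activity, read by MTT assay, with a stated time of 72 h (a higher number here means a weaker inhibitor, a lower number a stronger inhibitor), only a limit, > 40000 nM. The change considered here, (ethyl in place of trifluoromethoxy on an aromatic carbon), turns it into compound 3 `CCc1ccc(Nc2ncnc3cc(OC)c(OCCCCC(=O)Nc4ccc(S(N)(=O)=O)cc4)cc23)cc1`. Compound 1 `COc1cc2ncnc(Nc3ccc(F)c(Cl)c3)c2cc1OCCCCC(=O)Nc1ccc(S(N)(=O)=O)cc1` gives 15500 nM in this assay. Among the measured compounds shown here, the one measured step, an at least 2.5-fold higher number from compound 1 to compound 2 (0.41 log units; beyond the scatter), changed the same phenylamino group but toward trifluoromethoxy, so it says little about ethyl. With compound 2 sitting at the limit of > 40000 nM in this assay, at which 1 of the 2 values shown sits, no clear direction beyond the scatter is expected. The step of a number no higher from compound 2 to compound 3 (the limit leaves the size open) is therefore estimated as small. Compound 3 is expected at 40000 nM, between 12000 nM and 120000 nM.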

Compound 3, half-maximal inhibitory concentration: 12100 nM
The estimate for compound 3 lay 3.3-fold (0.52 log units) above the measured number; low and high end bracket the measured number.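

In this assay, ethyl in place of trifluoromethoxy on this aromatic carbon gives an at least 3.3-fold lower number from compound 2 to compound 3 (0.51 log units; beyond the scatter), so this change does move the read-out, though the exact size stays open because compound 2 carries only a limit of the assay: the limit of > 40000 nM in this assay, at which 1 of the 3 values shown sits.

The other new step, 4-ethylphenyl in place of 3-chloro-4-fluorophenyl, is a 1.3-fold lower number from compound 1 to compound 3 (0.11 log units; within the scatter), so these two groups cannot be told apart here.

On these data alone, whether a methyl group, a longer chain such as propyl, or an amine on the same carbon would read like ethyl remains open. So does what in trifluoromethoxy and ethyl sets the difference.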